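This account rests on a few compounds, and the source may have more. Where it says the series, first, only, none or still open, it means among the compounds named here.

Three compounds have been measured in an in vitro ADME assay on microsomes from liver (Homo sapiens) for metabolic stability, tested at 1 uM; a higher number here means that the compound lasts longer, a lower number that the compound disappears faster:

compound 1, `Cc1cc(CCC#N)cc(C)c1Oc1cc(Nc2ccc(C#N)cc2)c(N)cc1C(N)=O`: 0.7 h
compound 2, `Cc1cc(/C=C/C#N)cc(C)c1Oc1cc(Nc2ccc(C#N)cc2)c(N)cc1CO`: 0.503 h
compound 3, `Cc1cc(CCC#N)cc(C)c1Oc1cc(Nc2ccc(C#N)cc2)c(N)cc1CO`: 0.348 h

Compound 2 stands second of these three numbers in this assay; compound 1 gives a slightly higher number and compound 3 a slightly lower one, but both gaps lie within the usual scatter, so the three compounds cannot be told apart with confidence.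

Compound 4, `CNC(=O)c1cc(N)c(Nc2ccc(C#N)cc2)cc1Oc1c(C)cc(/C=C/C#N)cc1C`, has not yet been measured. It differs from compound 2 in one place: methylcarbamoyl in place of hydroxymethyl on an aromatic carbon. Among the compounds with values here, only one measured step touches the same ring carbon, the step of a 2.0-fold lower number from compound 1 to compound 3 (0.30 log units; within the scatter), in which carbamoyl gives way to hydroxymethyl. Compound 4 goes the other way, from hydroxymethyl to methylcarbamoyl, a group that shares the carbonyl and nitrogen of carbamoyl. The other step, a 1.4-fold lower number from compound 2 to compound 3 (0.16 log units; within the scatter), concerns the chain on the far ring and does not bear on this change. On that basis a number for compound 4 close to that of compound 2, if anything somewhat higher, is expected, with no shift beyond the scatter assured. Compound 4 is estimated to give 0.7 h in this assay, within 0.35 h to 1.4 h. This estimate means a step of a 1.4-fold higher number from compound 2 to compound 4 (0.14 log units; within the scatter).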

Compound 4, half-life: 0.747 h
Estimate against measurement, compound 4: 1.1-fold (0.03 log units) below; the measured number falls inside the stated range.
By their numbers in this assay, from the lowest: compounds 3, 2, 1 and 4 (each within the scatter of the next, the first and the last beyond it).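

At the ring carbon para to the (4-cyanophenyl)amino group, the change from hydroxymethyl to the larger methylcarbamoyl gives a 1.5-fold higher number from compound 2 to compound 4 (0.17 log units; within the scatter) in this assay, so this swap does not separate the two compounds. The position can now be read with each of the two chains: alongside 2-cyanoethyl the step between carbamoyl and hydroxymethyl is a 2.0-fold lower number from compound 1 to compound 3 (0.30 log units; within the scatter), and alongside 2-cyanoethenyl the new step also stays within the scatter, so neither pair shows a real difference at this carbon. Nothing at hand explains why the number stays so close through this change.

As far as these compounds go, it remains open whether any group at this position can shift the half-life clearly beyond the scatter, for example a carboxylic acid or an aminomethyl group in place of the amide. A longer chain on the amide nitrogen, such as ethyl or propyl in place of methyl, is a further open question, as is whether methylcarbamoyl behaves the same way alongside 2-cyanoethyl.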